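Cutting the long side chain short on a shared core

The source may report more compounds than this note shows. Statements on the series, on what has been measured and on what is new or still open speak of the compounds shown alone.

Compound 1 `Nc1nc2cc(-c3nn(CCCCCCCCCC(=O)NO)c4ncnc(N)c34)ccc2o1` was tested in a functional assay on A549 cells (Homo sapiens) for inhibition, read by MTT assay, with a stated time of 72 h; a higher number here means a weaker inhibitor, a lower number a stronger inhibitor. In this assay compound 1 gives > 50000 nM, which is a limit of the assay and not a number (the limit of > 50000 nM in this assay, at which 1 of the 3 values shown sits). Two related compounds carry a different aromatic group on the same core. Compound 2 `Nc1ncnc2c1c(-c1cnc3[nH]ccc3c1)nn2CCCCCCC(=O)NO` gives 50000 nM in this assay, and compound 3 `Nc1ncnc2c1c(-c1cnc3[nH]ccc3c1)nn2CCCCCCCCCC(=O)NO` gives 6550 nM. Two measured steps are known: an at least 7.6-fold lower number from compound 1 to compound 3 (0.88 log units; beyond the scatter) comes from swapping the aromatic group, and a 7.6-fold lower number from compound 2 to compound 3 (0.88 log units; beyond the scatter) comes from 3-(hydroxycarbamoyl)propyl in place of hydroxycarbamoyl on the chain.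

Compound 4 `Nc1nc2cc(-c3nn(CCCC(=O)NO)c4ncnc(N)c34)ccc2o1` has not yet been measured in this assay. It differs from compound 1 by hydroxycarbamoyl in place of 6-(hydroxycarbamoyl)hexyl on a saturated chain carbon, three bonds along the chain from an aromatic nitrogen. Only the second measured step concerns chain length, and it runs the other way: a longer chain brought a lower number in a 7.6-fold lower number from compound 2 to compound 3 (0.88 log units; beyond the scatter). Shortening the chain in compound 4 should therefore, if anything, raise the number, and with compound 1 already at the limit, no step beyond the scatter can be seen. Compound 4 is expected to give about 100000 nM, within a range from 50000 nM to 300000 nM, most likely reported again as a limit. This estimate means an expected step that the limit leaves unreadable from compound 1 to compound 4.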

Compound 4, half-maximal inhibitory concentration: > 100000 nM
Compound 4 was reported as a limit; the forecaster's own chance of this, stated with the estimate: 85%; the middle value sits exactly at the limit.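

In this assay compound 1 gives > 50000 nM, a limit and not a number. Compound 4 gives > 100000 nM, also a limit, so the step to it from the other compound cannot be read. The compounds shown leave open whether chain length matters at all with this aromatic group, since neither the 6-(hydroxycarbamoyl)hexyl nor the hydroxycarbamoyl version yields a number.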